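Swapping an Ether Link for a Methylene Bridge

The compounds below may be only part of what the source reports. "The series", "measured", "known", "first", "only" and "open" are said of these compounds alone.

Compound 1 `CC1(C)CC(Oc2ccc(C(=O)Nc3ccc(NC(=O)Nc4cc(C(C)(C)C)on4)cc3)nc2)CC(C)(C)N1`: 11 mL/min/kg
Compound 2 `CC(C)N1CCC(Oc2ccc(C(=O)Nc3ccc(NC(=O)Nc4cc(C(C)(C)C)on4)cc3)nc2)CC1`: 16 mL/min/kg

Both compounds share one core and differ only in the ring hung on the oxygen. In an in vivo ADME assay on the whole organism (plasma, strain Sprague-Dawley) for pharmacokinetics, with Rattus norvegicus as the target, read by LC-MS (on this read-out lower numbers stand for slow clearance and higher numbers for fast clearance), compound 2 sits at one end of this pair, yet the step of a 1.5-fold higher number from compound 1 to compound 2 (0.16 log units; within the scatter) is within the scatter, so no real difference between the two is shown.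

Compound 3 `CCN1CCC(Cc2ccc(C(=O)Nc3ccc(NC(=O)Nc4cc(C(C)(C)C)on4)cc3)nc2)CC1` has not been measured. It differs from compound 2 by (1-ethylpiperidin-4-yl)methyl in place of (1-isopropylpiperidin-4-yl)oxy on an aromatic carbon. Within the data shown here, no measured step covers a change of this kind; the only step available, a 1.5-fold higher number from compound 1 to compound 2 (0.16 log units; within the scatter), is within the scatter and offers no direction. The step expected in this assay is therefore a 1.1-fold higher number from compound 2 to compound 3 (0.05 log units; within the scatter), nothing beyond the scatter. Compound 3 is estimated at 18 mL/min/kg, within a range from 9 mL/min/kg to 36 mL/min/kg.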

Compound 3, clearance: 24 mL/min/kg
Beside the measured number, compound 3's estimate is 1.3-fold (0.12 log units) below it, and the stated range covers the measured number.
By their numbers in this assay, from the lowest: compounds 1, 2 and 3 (each within the scatter of the next, the first and the last beyond it).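

In this assay the ether oxygen can give way to the carbon link of (1-ethylpiperidin-4-yl)methyl with no real difference from the isopropyl ether, as a 1.5-fold higher number from compound 2 to compound 3 (0.18 log units; within the scatter) shows. Against the tetramethyl ether, however, the same group gives a 2.2-fold higher number from compound 1 to compound 3 (0.34 log units; beyond the scatter) and so provides the first modest difference at this aromatic carbon. No evidence is available to explain either step.

The link and the ring substituents change together here, so their separate contributions remain unresolved. On these data alone, how a morpholine ring or a carboxylic acid would behave at this position also remains open.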